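The source may report more compounds than this note shows. Statements on the series, on what has been measured and on what is new or still open speak of the compounds shown alone.

Compound 1 `CCn1c(-c2cnc(C)nc2)nc2c(N[C@H]3CCN(C(=O)N4CC(OC)C4)C3)ncnc21`: 0.7 L/kg
Compound 2 `CCn1c(-c2ccc(C(F)(F)F)nc2)nc2c(O[C@H]3CCN(C(=O)C4CCOC4)C3)ncnc21`: 0.2 L/kg

Within the data shown here, in an ADME assay (Rattus norvegicus, strain Wistar Han) for pharmacokinetics (a higher number here means that more of the compound sits outside the plasma, a lower number that more of the compound stays in the plasma), compound 1 gives 0.7 L/kg, the higher of the only two numbers available. Compound 2 gives 0.2 L/kg, and the gap between them lies beyond the usual scatter. Compound 1 therefore stands at the top of this small set, though a set of two says little about the range such compounds can reach.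

The next compound to be measured is compound 3 `CCn1c(-c2cnc(C)nc2)nc2c(N[C@H]3CCN(C(=O)C4CC4)C3)ncnc21`. It carries cyclopropyl in place of 3-methoxyazetidin-1-yl on a carbonyl carbon, while the rest of compound 1 stays the same. Among the measured compounds shown here, no pair of measured compounds differs in one place only, and compound 2 differs from compound 1 in several, so the data give no direct measure of this change. The starting point is therefore the value of compound 1, 0.7 L/kg. The expected step, a 1.1-fold higher number from compound 1 to compound 3 (0.06 log units; within the scatter), is small and not expected to go beyond the scatter in either direction. For compound 3 the estimated value is 0.8 L/kg, with an expected range from 0.4 L/kg to 1.5 L/kg.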

Compound 3, volume of distribution: 1 L/kg
Estimate against measurement, compound 3: 1.3-fold (0.10 log units) below; low and high end bracket the measured number.
By their numbers in this assay, from the lowest: compound 2; then compounds 1 and 3 (each within the scatter of the next).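

Read in this assay, the replacement of 3-methoxyazetidin-1-yl by cyclopropyl on a carbonyl carbon gives the first comparison in this series that changes one place only, a 1.4-fold higher number from compound 1 to compound 3 (0.15 log units; within the scatter) and it stays within the scatter. Compound 1 and compound 3 therefore cannot be told apart in this read-out, although the group on the carbonyl carbon goes from 6 heavy atoms to 3, loses its nitrogen and oxygen, and goes from 1 hydrogen-bond acceptor to 0. For this single pair, then, an amide-type nitrogen in a four-membered ring and a carbocyclic three-membered ring on the carbonyl carbon give numbers that the assay does not separate, and no measurement offered here bears on the reason for this result.

From the compounds shown here alone, it remains open whether a group of another kind at this place, such as a primary amine, a carboxylic acid or a longer alkyl chain, would give a step beyond the scatter. Going by these compounds, it is also open whether the same exchange would give a comparable step with the other parts of compound 2 in place.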